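Fluoro for trifluoromethyl on the cinnamoyl-side aromatic ring

A few compounds are considered here, and "the series" means these few. Any claim that something is new, unique, unknown or untested is made for them only; others in the source may bear on it.

Compound 2 `CC1=C(/C=C/C(=O)/C=C/c2cc(C(F)(F)F)ccc2C(F)(F)F)C(C)(C)CCC1O` gives 1900 nM in a functional assay on PC-3 cells (Homo sapiens) for cytotoxicity, read by MTT assay, with a stated time of 72 h (a lower number here means a stronger inhibitor, a higher number a weaker inhibitor), the lowest of the three numbers measured. Compound 1 `CC1=C(/C=C/C(=O)/C=C/c2ccccc2C(F)(F)F)C(C)(C)CCC1O` gives 3700 nM, and the step of a 1.9-fold lower number from compound 1 to compound 2 (0.29 log units; within the scatter) is within the scatter. Going by the values given here, compound 3 `CC1=C(/C=C/C(=O)/C=C/c2ccc(F)cc2)C(C)(C)CCC1O`, which carries a fluoro on its aromatic ring, gives 6200 nM, a higher number than compound 2, beyond the scatter; no single-change step links compound 3 to compound 1 or compound 2.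

Compound 4 `CC1=C(/C=C/C(=O)/C=C/c2cc(C(F)(F)F)ccc2F)C(C)(C)CCC1O` differs from compound 2 by fluoro in place of trifluoromethyl on an aromatic carbon. Among the compounds with values here, the only step that bears on it is a 1.9-fold lower number from compound 1 to compound 2 (0.29 log units; within the scatter), which shows that a trifluoromethyl at that carbon moved the number very little. Removing most of that group and leaving a fluoro is therefore expected to give at most a small step in this assay, if anything toward a higher number, with compound 3 as the only hint that a fluoro-bearing ring can sit higher. For compound 4 the expected step is a 1.5-fold higher number from compound 2 to compound 4 (0.17 log units; within the scatter), and the estimate is 2800 nM, with a range from 1300 nM to 6000 nM.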

Compound 4, half-maximal inhibitory concentration: 3600 nM
Compound 4: middle estimate off by 1.3-fold (0.11 log units), on the low side; the measured number falls inside the stated range.
By their numbers in this assay, from the lowest: compounds 2, 4, 1 and 3 (each within the scatter of the next, the first and the last beyond it).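

In this assay, going by these compounds alone, the step of a 1.9-fold higher number from compound 2 to compound 4 (0.28 log units; within the scatter) is the first reading at this carbon itself, ortho to a large group and para to a trifluoromethyl group, since the earlier step changed a different carbon of the ring. Trifluoromethyl (4 heavy atoms) and fluoro (1 heavy atom) cannot be told apart here in this assay, so this carbon tolerates that drop in group size without a change beyond the scatter. No measurement available here bears on why the swap has so little effect.

Still open, going by these compounds, is whether any group at this carbon can move the number beyond the scatter, for instance an amine, a carboxylic acid or a methoxy group. Also open, on these data alone, is whether the same swap would read alike without the trifluoromethyl group para to this carbon.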